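A few compounds are considered here, and "the series" means these few. Any claim that something is new, unique, unknown or untested is made for them only; others in the source may bear on it.

Series notes. Compound 1, `NC(=O)/C=C/c1ccncc1-c1ccc2ccccc2c1`, carries a primary amide on the unsaturated chain. In a functional assay on HCT-116 cells (Homo sapiens) for inhibition, read by MTT assay, with a stated time of 72 h (on this read-out higher numbers stand for weaker inhibition of growth and lower numbers for stronger inhibition of growth), compound 1 gives 12100 nM, the highest of the two numbers recorded so far. For the measured compounds named here, the only other measured member, compound 2, `CCOC(=O)/C=C/c1ccncc1-c1ccc2c(ccn2C)c1`, gives 210 nM in this assay, a lower number lying beyond the usual scatter; compound 2 differs from compound 1 at both the carbonyl substituent and the ring system, so no single-change step connects the two. Compound 3, `COC1CN(C(=O)/C=C/c2ccncc2-c2ccc3ccccc3c2)C1`, keeps the core of compound 1 and alters only the amide: 3-methoxyazetidin-1-yl in place of amino on a carbonyl carbon. Going by the values given here, with no matched pair on record, the direction can only be guessed; a modest move towards a lower number in this assay is expected, since the single lower value belongs to an ester with no hydrogen-bond donor, but that compound also carries a different ring. The expected step is a 3.0-fold lower number from compound 1 to compound 3 (0.48 log units; beyond the scatter). Compound 3 is estimated at 4000 nM, with a range from 600 nM to 20000 nM.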

Compound 3, concentration for 50% growth inhibition: > 30000 nM
Compound 3 gave a limit, no number; the forecaster's own chance of this, stated with the estimate: 5%; middle value at least 7.5-fold (0.87 log units) from the limit.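

For the compounds shown here, at this carbonyl carbon, the single change from amino to 3-methoxyazetidin-1-yl on the core of compound 1 gives, in this assay, an at least 2.4-fold higher number from compound 1 to compound 3 (0.39 log units; beyond the scatter). Going by these compounds alone, this is the first reading of one change at this position, and it runs towards weaker inhibition of growth, not stronger. Its size is only a bound, as compound 3 has a limit of the assay and not a number: the limit of > 30000 nM in this assay, at which 1 of the 3 values shown sits.

The compounds shown do not separate the azetidine ring, the methoxy group and the loss of the amide hydrogen as sources of this step. Going by these compounds, a methylamino group, a dimethylamino group or an unsubstituted azetidin-1-yl on the same carbonyl carbon would bear on that, and how far compound 3 lies past its limit remains open.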